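Fluorine Beside Nothing Else: A Small Change on a Weak Modulator

This account rests on a few compounds, and the source may have more. Where it says the series, first, only, none or still open, it means among the compounds named here.

Three compounds share a four-carbon linker joining two aromatic ends. Compound 1 `COc1cc(C(=O)O)ccc1OCCCCOc1ccc(C(=O)C(C)C)c(O)c1C` gives 25.6% in an assay on HEK293 cells for positive allosteric modulation of metabotropic glutamate receptor 3 (Rattus norvegicus), read by thallium flux, with a stated time of 2.5 min; on this read-out higher numbers stand for larger maximal responses and lower numbers for smaller maximal responses. Compound 2 `CCCC(=O)c1ccc(OCCCCOc2cccc(C(=O)O)c2C)c(C)c1O` gives 53% in this assay. Compound 3 `Cc1c(OCCCCOc2cccc(C(=O)O)c2)ccc(C(=O)CC(C)C)c1C` gives 18.3% in this assay, the lowest of the three numbers: its distance from compound 1 lies within the usual scatter, while its distance from compound 2 lies beyond it. So compound 3 and compound 1 cannot be told apart on this read-out, and only compound 2 stands clearly above both.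

Compound 4 `Cc1c(OCCCCOc2ccc(F)c(C(=O)O)c2)ccc(C(=O)CC(C)C)c1C` has not yet been tested. It differs from compound 3 in one place: fluoro in place of hydrogen on an aromatic carbon.

No pair in the measured set differs by exactly this change, so its effect cannot be read from the numbers shown. A single fluorine entering with no ring, no donors and no acceptors is a small addition, and with no comparable step shown, the expectation is for a step in this assay that stays within the usual scatter in either direction. On that basis compound 4 is expected to give a maximal response of 21%, with a range of 8% to 38%, a step of a number 2.7 percentage points higher from compound 3 to compound 4 (within the scatter) that is estimated rather than known.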

Compound 4, largest response reached (reported as percent of maximum), in percent of the reference or control that the assay uses: 13.8%
The estimate for compound 4 lay 7.2 percentage points above the measured number; measured number inside the range.
By their numbers in this assay, from the lowest: compounds 4, 3 and 1 (each within the scatter of the next, the first and the last beyond it); then compound 2.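

Compound 4 gives the set its first comparison that changes only one place, and the result is a step of a number 4.5 percentage points lower from compound 3 to compound 4 (within the scatter) in this assay. At this carbon, ortho to a carboxy group and para to a large group, the change from 3-carboxyphenyl to 3-carboxy-4-fluorophenyl therefore leaves compound 4 indistinguishable from compound 3 on this read-out, so a fluoro group is tolerated here without any clear gain or loss in maximal response, at least on this one background. Nothing in the data shown bears on why the response behaves this way at this carbon.

The compounds shown leave open whether a chlorine atom, a methoxy group or an amine on this same aromatic carbon would also stay within the scatter of compound 3, and whether fluoro in place of hydrogen would do so on the core of compound 2, whose response stands clearly higher. They also leave open which of the several differences between compound 2 and the other compounds accounts for that higher response, since no pair shown isolates any one of them.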